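A ring-nitrogen substituent swap and the expected cytotoxic read-out

The source may report more compounds than this note shows. Statements on the series, on what has been measured and on what is new or still open speak of the compounds shown alone.

Going by the values given here, compound 2 `CN(C)/C=C/N1CCN(CC(=O)Nc2ccc(-c3nc(-c4ccccc4)c(-c4ccccc4)n3C)cc2)CC1` stands lowest of the two numbers measured so far: in a functional assay on HT-29 cells (Homo sapiens) for cytotoxicity, read by MTT assay, with a stated time of 24 h, tested at 6.4 ug/mL (on this read-out higher numbers stand for a stronger effect at the one concentration tested and lower numbers for a weaker effect), compound 2 gives 12.2%. Among the compounds with values here, its only neighbour, compound 1 `CN1CCN(CC(=O)Nc2ccc(-c3nc(-c4ccccc4)c(-c4ccccc4)n3C)cc2)CC1`, differs from it solely on an amine nitrogen in a ring, and in this assay compound 1 gives 28.8%; the step between them is a number 16.6 percentage points lower from compound 1 to compound 2 (beyond the scatter). Compound 3 `Cc1ccc(CN2CCN(CC(=O)Nc3ccc(-c4nc(-c5ccccc5)c(-c5ccccc5)n4C)cc3)CC2)cc1` is not yet measured. It differs from compound 2 in one place: 4-methylbenzyl in place of 2-(dimethylamino)ethenyl on an amine nitrogen in a ring. Within the data shown here, only one measured step touches this ring nitrogen, namely a number 16.6 percentage points lower from compound 1 to compound 2 (beyond the scatter), and it tells what 2-(dimethylamino)ethenyl in place of methyl did, not what 4-methylbenzyl will do. Lacking a measured step for 4-methylbenzyl, the expectation for compound 3 rests loosely on the levels of compound 1 and compound 2, so a step of a number 9.8 percentage points higher from compound 2 to compound 3 (within the scatter) back toward the middle of that pair is expected, possibly within the scatter. Compound 3 is therefore estimated at 22% in this assay, within 8% to 40%.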

Compound 3, a percentage reported as activity, at one concentration (the size of the read-out at that concentration, not a potency): 27.7%
Compound 3: the middle estimate sits 5.7 percentage points below what was measured; the range from low to high includes it.
By their numbers in this assay, from the lowest: compound 2; then compounds 3 and 1 (each within the scatter of the next).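

On an amine nitrogen in a ring, in this assay, 4-methylbenzyl in place of 2-(dimethylamino)ethenyl gives a clear rise (a number 15.5 percentage points higher from compound 2 to compound 3 (beyond the scatter)). Read against compound 1, the 4-methylphenyl in place of hydrogen on the saturated chain carbon leaves the read-out within the scatter (a number 1.1 percentage points lower from compound 1 to compound 3 (within the scatter)), so methyl and 4-methylbenzyl cannot be told apart here, and compound 2 alone stands apart among the three. Nothing measured accounts for this difference.

On these data alone, whether the lower read-out of compound 2 follows the dimethylamino group or the double bond of its chain remains open. Also open, as far as these compounds go, is what an unsubstituted benzyl, a plain hydrogen or a longer alkyl chain on this nitrogen would give, and how these numbers would change at other concentrations.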